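A few compounds are considered here, and "the series" means these few. Any claim that something is new, unique, unknown or untested is made for them only; others in the source may bear on it.

Working notes on the series. In a functional assay on HeLa cells (Homo sapiens) for antiproliferative activity, read by MTT assay, with a stated time of 72 h (on this read-out lower numbers stand for stronger inhibition and higher numbers for weaker inhibition), compound 1 `Cc1ccc2c(=O)c(CSC(=S)N(C(C)C)C(C)C)coc2c1` gives 1400 nM. Compound 2 `COc1ccc2occ(CSC(=S)N(C(C)C)C(C)C)c(=O)c2c1` gives 5400 nM in this assay. Compound 3 `CC(C)N(C(=S)SCc1coc2ccccc2c1=O)C(C)C` reports > 30000 nM in this assay, and this value is a limit of the assay rather than a number (the limit of > 30000 nM in this assay, at which 1 of the 3 values shown sits). Both measured steps end at compound 3 and both alter an aromatic carbon: an at least 21-fold higher number from compound 1 to compound 3 (1.33 log units; beyond the scatter), and an at least 5.5-fold higher number from compound 2 to compound 3 (0.74 log units; beyond the scatter).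

Compound 4 `O=c1c(CSC(=S)N2CCCCC2)coc2ccccc12` is the next member, to be measured in this assay. The change from compound 3 is piperidin-1-yl in place of diisopropylamino on a thiocarbonyl carbon. For the measured compounds named here, neither measured step involves the thiocarbonyl carbon, so neither bears directly on this change; the only anchor is that compound 3 stands at the limit. No step beyond the scatter is expected, so compound 4 is estimated to remain at or near the limit, a step of a number no higher from compound 3 to compound 4 (the limit leaves the size open). Compound 4 is estimated at 30000 nM, within a range of 10000 nM to 100000 nM, with a substantial chance that only a limit is again reported.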

Compound 4, half-maximal inhibitory concentration: 2300 nM
Compound 4: middle estimate off by 13-fold (1.12 log units), on the high side, outside the stated range (below it).
By their numbers in this assay, from the lowest: compounds 1 and 4 (each within the scatter of the next); then compound 2. At a limit, above all of these: compound 3.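

The thiocarbonyl carbon is a second place in the series where a single change moves the read-out in this assay, with an at least 13-fold lower number from compound 3 to compound 4 (1.11 log units; beyond the scatter) on piperidin-1-yl replacing diisopropylamino. Compound 4 carries neither the methyl of compound 1 nor the methoxy of compound 2, so with piperidin-1-yl on the thiocarbonyl carbon neither group is needed for a measurable number, and compound 4 gives 2300 nM in this series. As far as these compounds go, the value of compound 3 is a limit of the assay and not a number, so the full size of this step stays open: the limit of > 30000 nM in this assay, at which 1 of the 4 values shown sits.

From the compounds shown here alone, whether the ring itself carries the step remains open, and an open-chain diethylamino or a morpholin-4-yl group on the thiocarbonyl carbon would bear on that. Also open, going by these compounds, is whether methyl or methoxy on an aromatic carbon still lowers the number when piperidin-1-yl is present.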